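This account rests on a few compounds, and the source may have more. Where it says the series, first, only, none or still open, it means among the compounds named here.

Measured in a functional assay on RS4-11 cells (Homo sapiens) for inhibition, read by CCK-8 assay, with a stated time of 48 h; on this read-out lower numbers stand for stronger inhibition and higher numbers for weaker inhibition:
- compound 1 `COc1ccc(Oc2ccccc2-c2ccsc2S(=O)(=O)N2CCN(C(=S)Nc3ccc([N+](=O)[O-])cc3)CC2)cc1OC`: > 50000 nM (a limit)
- compound 2 `O=[N+]([O-])c1ccc(NC(=S)NCCNS(=O)(=O)c2ccc(-c3ccccc3O[C@H]3CC[C@@H](O)CC3)s2)cc1`: 9400 nM
- compound 3 `COc1ccc(Oc2ccc([N+](=O)[O-])cc2-c2ccsc2S(=O)(=O)N2CCN(C(=S)Nc3ccc([N+](=O)[O-])cc3)CC2)cc1OC`: > 50000 nM (a limit)

Compound 1 has no number in this assay, only the limit > 50000 nM. The picture around it is the limit of > 50000 nM in this assay, at which 2 of the 3 values shown sit. Within the data shown here, compound 2, at 9400 nM, goes against that picture, but it differs from compound 1 in more than one place and gives no step to use.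

Compound 4 `COc1ccc(Oc2ccccc2-c2ccsc2S(=O)(=O)N2CCN(C(=O)Nc3ccc(F)cc3)CC2)cc1OC` keeps the core of compound 1 and changes one group, on an amine nitrogen in a ring: a group of 10 heavy atoms (7 carbon, 1 nitrogen, 1 oxygen, 1 fluorine; one six-membered aromatic ring of carbon only) in place of a group of 12 heavy atoms (7 carbon, 2 nitrogen, 2 oxygen, 1 sulfur; one six-membered aromatic ring of carbon only), on an amine nitrogen in a ring. The group that enters is (4-fluorophenyl)carbamoyl.

Among the measured compounds shown here, the only measured step is a step that the two limits leave unreadable from compound 1 to compound 3. It has no readable size and does not touch that ring nitrogen, so it says nothing about this change. No direction can therefore be drawn from the measured steps in this assay. The expectation rests on compound 1 and its limit of > 50000 nM, and compound 4 is expected to stay close to that limit, possibly reported as a limit itself. The estimated step is a number no higher from compound 1 to compound 4 (the limit leaves the size open), and no readable change is expected from it. For compound 4 the estimated value is 50000 nM, with an expected range from 15000 nM to 100000 nM.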

Compound 4, half-maximal inhibitory concentration: 14900 nM
For compound 4 the middle estimate is 3.4-fold (0.53 log units) above the measured one; the whole stated range lies above it.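

In this assay, among these compounds, putting (4-fluorophenyl)carbamoyl on the amine nitrogen in the ring gives an at least 3.3-fold lower number from compound 1 to compound 4 (0.52 log units; beyond the scatter), the first readable evidence that the number responds to a change at this position. The entering group keeps the six-membered aromatic ring of carbon only and the hydrogen-bond donor of the group that leaves, but it is smaller, with fewer hydrogen-bond acceptors and fewer double bonds outside aromatic rings. The shared core therefore now has a measured number with this group, where the earlier values on that core gave only limits: the limit of > 50000 nM in this assay, at which 2 of the 4 values shown sit.

The other step among these compounds cannot be read, and the one readable step replaces the whole group at once, so it does not separate the exchange of sulfur for oxygen from the arrival of fluorine on the aromatic ring. As far as these compounds go, it also remains open how this assay would respond to a carboxylic acid in place of that fluorine, or to a longer chain on the same ring nitrogen.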